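This account rests on a few compounds, and the source may have more. Where it says the series, first, only, none or still open, it means among the compounds named here.

Of the compounds shown here, two of a shared core have been measured in a physicochemical assay for metabolic stability, read by HPLC, in phosphate buffer, at pH 7.7; on this read-out lower numbers stand for a shorter-lived compound and higher numbers for a longer-lived compound. Compound 1, `CCCC(=O)N[C@@H](C)C(=O)N(C)/N=N/c1ccc(C#N)cc1`, gives 9.1 h in this assay. Compound 2, `CC(=O)N[C@@H](C)C(=O)N(C)/N=N/c1ccc(C(N)=O)cc1`, gives 18.4 h and so stands highest of the two numbers; compound 1 sits a step below it that lies beyond the usual scatter. For the measured compounds named here, compound 1 and compound 2 differ in more than one place, so the two values show only that compound 2 is the longer-lived of the pair. Compound 3, `CC(=O)N[C@@H](C)C(=O)N(C)/N=N/c1ccc(C)cc1`, is not yet measured; it differs from compound 2 by methyl in place of carbamoyl on an aromatic carbon. Going by the values given here, no measured pair in this set carries that single change, so nothing here shows its direction. For compound 3 the expectation is a step of a 1.3-fold lower number from compound 2 to compound 3 (0.12 log units; within the scatter) in this assay, small enough to fall within the scatter. Compound 3 is therefore estimated at 14 h, with a range from 7 h to 30 h.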

Compound 3, half-life: 46.5 h
Compound 3: the middle estimate sits 3.3-fold (0.52 log units) below what was measured, outside the stated range (above it).
By their numbers in this assay, from the lowest: compound 1; then compound 2; then compound 3.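

For the compounds shown here, this is the first change in the set made in one place only, so the group on this aromatic carbon, para to a large group, can now be judged on its own. In this assay, methyl in place of carbamoyl gives a 2.5-fold higher number from compound 2 to compound 3 (0.40 log units; beyond the scatter), which shows that the group at this position can shift the half-life by more than the usual scatter. Nothing measured here explains why the number rises.

Going by these compounds, how an amine, a carboxylic acid or a longer chain on this carbon would compare remains open. On these data alone, it is also open whether methyl would give a step in the same direction on the core of compound 1, which carries a nitrile at this position and has a longer acyl chain.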